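A few compounds are considered here, and "the series" means these few. Any claim that something is new, unique, unknown or untested is made for them only; others in the source may bear on it.

Compound 3 `CCN(CC)CN1C(=O)/C(=N/NC(=S)Nc2ccccc2)c2ccccc21` gives 1600 nM in an ADME assay on MDCK cells (Canis lupus familiaris) for cytotoxicity (on this read-out lower numbers stand for higher toxicity in this test and higher numbers for lower toxicity in this test), and stands at the low end of the three numbers shown; compound 1 `CCN(CC)CN1C(=O)/C(=N/NC(N)=S)c2ccccc21` gives 85800 nM, compound 2 `CCN(CC)CN1C(=O)/C(=N/NC(=S)Nc2ccccc2)c2cc(Cl)ccc21` gives 3000 nM. The step of a 54-fold lower number from compound 1 to compound 3 (1.73 log units; beyond the scatter) is large, whereas the step of a 1.9-fold lower number from compound 2 to compound 3 (0.27 log units; within the scatter) does not leave the scatter. Compound 4 `CCN(CC)CN1C(=O)/C(=N/NC(=S)Nc2ccc(C)cc2)c2ccccc21` differs from compound 3 by methyl in place of hydrogen on an aromatic carbon. Among the measured compounds shown here, no measured step shows a methyl entering; the one change on an aromatic carbon, a 1.9-fold lower number from compound 2 to compound 3 (0.27 log units; within the scatter), stayed within the scatter, and the large step came from phenyl in place of hydrogen on the amide-type nitrogen, which compound 3 and compound 4 share. For compound 4 in this assay a step of no change at the digits printed from compound 3 to compound 4 (within the scatter) is therefore expected, none beyond the scatter. Compound 4 is estimated at 1600 nM, between 700 nM and 3600 nM.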

Compound 4, half-maximal cytotoxic concentration: 200 nM
The estimate for compound 4 lay 8.0-fold (0.90 log units) above the measured number; measured number outside the range, below it.
By their numbers in this assay, from the lowest: compound 4; then compounds 3 and 2 (each within the scatter of the next); then compound 1.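

In this assay, the phenyl on the thiourea-type nitrogen proves sensitive to a single added carbon: methyl in place of hydrogen, para to a large group, gives an 8.0-fold lower number from compound 3 to compound 4 (0.90 log units; beyond the scatter) and leaves the scatter, unlike the earlier aromatic change on the core, a 1.9-fold lower number from compound 2 to compound 3 (0.27 log units; within the scatter) within it. Adding this methyl extends the effect of the aryl group, since 4-methylphenyl in place of hydrogen gives a 430-fold lower number from compound 1 to compound 4 (2.63 log units; beyond the scatter) against a 54-fold lower number from compound 1 to compound 3 (1.73 log units; beyond the scatter) for phenyl. No evidence is available on what lies behind this step.

As far as these compounds go, whether the shift is specific to methyl remains open. Methoxy, chloro or a carboxylic acid at this carbon would test that, and an ethyl would show whether a longer chain goes further.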